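The source may report more compounds than this note shows. Statements on the series, on what has been measured and on what is new or still open speak of the compounds shown alone.

Measured in a functional assay on PC-9 cells (Homo sapiens) for inhibition, read by MTT assay, with a stated time of 72 h; a lower number here means a stronger inhibitor, a higher number a weaker inhibitor:
- compound 1 `Cc1cc(Nc2cc(-c3ccccc3)[nH]n2)n2nc(SCC3CCCCC3)nc2n1`: > 50000 nM (a limit)
- compound 2 `Cc1cc(Nc2cc(-c3ccccc3)[nH]n2)n2nc(SCc3ccc(Br)cc3)nc2n1`: 4760 nM
- compound 3 `C#CCSc1nc2nc(C)cc(Nc3cc(-c4ccccc4)[nH]n3)n2n1`: > 50000 nM (a limit)

Compound 3 gives no number in this assay and stands at the limit of > 50000 nM in this assay, at which 2 of the 3 values shown sit. Its true position is therefore unknown. The next compound is compound 4 `Cc1cc(Nc2cc(-c3ccccc3)[nH]n2)n2nc(SCc3nc4ccccc4[nH]3)nc2n1`, and the change is 1H-benzimidazol-2-yl in place of ethynyl on a saturated chain carbon bound to a sulfur, with 1H-benzimidazol-2-yl in place of ethynyl on a saturated chain carbon bound to a sulfur.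

Among the measured compounds shown here, two measured steps bear on this change. The closest is an at least 10-fold higher number from compound 2 to compound 3 (1.02 log units; beyond the scatter), large and beyond the scatter, with ethynyl in place of 4-bromophenyl. The second is an at least 10-fold lower number from compound 1 to compound 2 (1.02 log units; beyond the scatter), also large, with 4-bromophenyl in place of cyclohexyl. The third, a step that the two limits leave unreadable from compound 1 to compound 3, offers no readable size. Only compound 2 has so far given a number, and its aromatic ring is not the one that enters here. Compound 1 goes against any idea that a ring alone is enough, since it also carries one and stands at > 50000 nM, which is a limit.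

A large move towards a lower number is therefore expected, though compound 4 may also remain at the limit. The expected step is an at least 5.5-fold lower number from compound 3 to compound 4 (0.74 log units; beyond the scatter). Compound 4 is estimated at 9000 nM, with an expected range from 2500 nM to 40000 nM.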

Compound 4, half-maximal inhibitory concentration: 4840 nM
The estimate for compound 4 lay 1.9-fold (0.27 log units) above the measured number; measured number inside the range.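

Placed on the saturated chain carbon bound to a sulfur, 1H-benzimidazol-2-yl gives a readable number in this assay, with an at least 10-fold lower number from compound 3 to compound 4 (1.01 log units; beyond the scatter) and an at least 10-fold lower number from compound 1 to compound 4 (1.01 log units; beyond the scatter); each of these steps starts from a limit and not from a number: the limit of > 50000 nM in this assay, at which 2 of the 4 values shown sit.

4-Bromophenyl is thus no longer the only group at this place to give a number, and the two groups cannot be told apart, with a 1.0-fold higher number from compound 2 to compound 4 (0.01 log units; within the scatter). Among these four compounds, the two groups with an aromatic ring give numbers while cyclohexyl and ethynyl stay at the limit, and no compound shown goes against this pattern, although four compounds are a small set.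

Where compound 1 and compound 3 truly stand remains open, so the full size of the two large steps is unknown. Also open, on these data alone, is whether an unsubstituted phenyl, a pyridine ring or a longer chain between the sulfur and the ring would give a number in this assay.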